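The source may report more compounds than this note shows. Statements on the series, on what has been measured and on what is new or still open speak of the compounds shown alone.

Measured compounds:
- compound 1, `CCNc1cc(C#Cc2ccc(F)s2)nc2c1ncn2[C@H]1[C@H](O)[C@H](O)[C@]2(C(=O)NC)C[C@H]12`: 2.78 nM
- compound 2, `CNC(=O)[C@H]1O[C@@H](n2cnc3c(NC)cc(C#Cc4ccc(F)s4)nc32)[C@H](O)[C@@H]1O`: 26.6 nM
- compound 3, `CCOC(=O)[C@@]12C[C@@H]1[C@@H](n1cnc3c(NC)nc(C#Cc4ccc(F)s4)nc31)[C@H](O)[C@@H]2O`: 10.4 nM

All three numbers come from an assay on CHO cells for displacement of a labelled ligand from adenosine receptor A3 (Homo sapiens); on this read-out lower numbers stand for stronger inhibition and higher numbers for weaker inhibition. Compound 1 stands lowest of the three; compound 3 is nearest to it with a higher number, compound 2 furthest with a higher number still, and both gaps lie beyond the usual scatter. Compound 2 and compound 3 each differ from compound 1 in more than one place, so no single change can be read off from them.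

Compound 4, `CNC(=O)[C@@]12C[C@@H]1[C@@H](n1cnc3c(NC)cc(C#Cc4ccc(F)s4)nc31)[C@H](O)[C@@H]2O`, differs from compound 1 in one place: hydrogen in place of methyl on a saturated chain carbon bound to a nitrogen on an aromatic ring. Among the measured compounds shown here, no measured pair in the set is separated by this change alone, so there is no precedent within these data for its size. Compound 2 and compound 3 both carry the methylamino group, but their other differences from compound 1 leave their values uninformative on this point. The step of a 1.1-fold higher number from compound 1 to compound 4 (0.03 log units; within the scatter) is therefore expected to be small, in either direction, and not beyond the scatter. Compound 4 is expected to give 3 nM in this assay, within a range from 1 nM to 10 nM.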

Compound 4, inhibition constant: 0.896 nM
Estimate against measurement, compound 4: 3.3-fold (0.52 log units) above; the whole stated range lies above it.
By their numbers in this assay, from the lowest: compound 4; then compound 1; then compound 3; then compound 2.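

In this assay the change from ethylamino to methylamino gives a 3.1-fold lower number from compound 1 to compound 4 (0.49 log units; beyond the scatter). Among the compounds shown here, this is the first reading of this chain on its own, and it shows that removing one carbon at this position moves the number beyond the scatter, towards stronger inhibition. No available evidence accounts for the size or direction of this step.

One pair gives two points and no trend, so a free amino group or a longer chain such as propyl would be needed to show whether the number keeps falling as the chain shortens and rising as it lengthens. Going by these compounds, it also remains open whether the same change gives a step of similar size on a different core, since only the core of compound 1 provides a reading.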